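A few compounds are considered here, and "the series" means these few. Any claim that something is new, unique, unknown or untested is made for them only; others in the source may bear on it.

In a functional assay on MCF7 cells (Homo sapiens) for antiproliferative activity, read by MTT assay, with stated times of 24 h and 72 h (a higher number here means a weaker inhibitor, a lower number a stronger inhibitor), three compounds built on a shared core have been measured. Compound 1 `COc1cc(N2C(=O)[C@@H](Oc3ccccc3)[C@H]2c2ccc(Br)cc2)cc(OC)c1OC` gives 48000 nM, compound 2 `COc1cc(N2C(=O)[C@@H](Oc3ccccc3)[C@H]2c2ccc(C#N)cc2)cc(OC)c1OC` gives 31600 nM, and compound 3 `COc1cc(N2C(=O)[C@@H](Oc3ccccc3)[C@H]2c2ccc(O)cc2)cc(OC)c1OC` gives 48000 nM, which places compound 3 level with compound 1 and within the scatter of compound 2. Compound 4 `COc1cc([C@@H]2[C@H](Oc3ccccc3)C(=O)N2c2cc(OC)c(OC)c(OC)c2)ccc1O` has methoxy in place of hydrogen on an aromatic carbon, ortho to the hydroxy group, turning 4-hydroxyphenyl into 4-hydroxy-3-methoxyphenyl (methoxy in place of hydrogen on an aromatic carbon). The closest guides are swaps of one group on that ring: a 1.5-fold lower number from compound 1 to compound 2 (0.18 log units; within the scatter), no change at the digits printed from compound 1 to compound 3 (within the scatter) and a 1.5-fold higher number from compound 2 to compound 3 (0.18 log units; within the scatter), all within the scatter. None of them adds a group to compound 3, so they guide only loosely. The estimated step is a 1.6-fold lower number from compound 3 to compound 4 (0.20 log units; within the scatter), and none beyond the scatter is expected. For compound 4 the estimate is 30000 nM, with an expected range from 8000 nM to 60000 nM.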

Compound 4, half-maximal inhibitory concentration: 32000 nM
The estimate for compound 4 lay 1.1-fold (0.03 log units) below the measured number, within the range that was stated.
By their numbers in this assay, from the lowest: compounds 2, 4, 1 and 3 (each within the scatter of the next).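

In this assay, among these compounds, methoxy in place of hydrogen, ortho to a hydroxy group, gives a 1.5-fold lower number from compound 3 to compound 4 (0.18 log units; within the scatter), so this aromatic carbon takes an added group with a step that stays within the scatter, whereas the earlier steps only swapped one group for another. The larger 4-hydroxy-3-methoxyphenyl in place of 4-cyanophenyl gives a 1.0-fold higher number from compound 2 to compound 4 (0.01 log units; within the scatter), and in place of 4-bromophenyl it gives a 1.5-fold lower number from compound 1 to compound 4 (0.18 log units; within the scatter), leaving all four compounds within the scatter of one another. Nothing available explains this result.

Going by these compounds, what an amine, a carboxylic acid or a longer chain than methoxy would give at this place stays open. So does whether any group here can produce a step beyond the scatter.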